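Swapping One Ring Group on a Shared Core

The compounds below may be only part of what the source reports. "The series", "measured", "known", "first", "only" and "open" are said of these compounds alone.

Of the compounds shown here, three built on one shared core have been tested in a functional assay on PC-3 cells (Homo sapiens) for cytotoxicity, read by MTT assay, with a stated time of 72 h; a lower number here means a stronger inhibitor, a higher number a weaker inhibitor. Compound 1 `CCCCCCCCCCCCNc1nc(SCc2ccc(C(F)(F)F)cc2)nc2ccccc12` gives 26000 nM in this assay. Compound 2 `CCCCCCCCCCCCCCNc1nc(SCc2ccc(C(F)(F)F)cc2)nc2ccccc12` reaches only a limit of the assay, > 50000 nM, and not a number. Compound 2 sits at the limit of > 50000 nM in this assay, at which 1 of the 3 values shown sits. For the measured compounds named here, the step of an at least 1.9-fold higher number from compound 1 to compound 2 (0.28 log units; that floor lies within the scatter) is the one measured change of a single group in this set. Compound 3 `FC(F)(F)c1ccc(CSc2nc(Nc3cccc(Br)c3)c3ccccc3n2)cc1` gives 8680 nM, the lowest of the two numbers recorded, with compound 1 as its nearest neighbour at a gap beyond the scatter.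

Compound 4 `COc1ccc(Nc2nc(SCc3ccc(C(F)(F)F)cc3)nc3ccccc23)cc1OC` has not yet been measured. It differs from compound 3 in one place: 3,4-dimethoxyphenyl in place of 3-bromophenyl on a nitrogen on an aromatic ring. Going by the values given here, no measured step touches this part of the molecule; the only step recorded concerns the saturated chain of compound 1 and compound 2, so it offers no guide to replacing one ring group by another. With nothing to lean on, the expected step from compound 3 is small and in no particular direction, and the expectation is written as a 1.2-fold higher number from compound 3 to compound 4 (0.06 log units; within the scatter). Compound 4 is therefore estimated at 10000 nM in this assay, with a range from 3000 nM to 35000 nM.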

Compound 4, half-maximal inhibitory concentration: 14100 nM
Compound 4: the middle estimate sits 1.4-fold (0.15 log units) below what was measured, and the stated range covers the measured number.
By their numbers in this assay, from the lowest: compounds 3, 4 and 1 (each within the scatter of the next, the first and the last beyond it). At a limit, above all of these: compound 2.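

Unlike the earlier step along the saturated chain, this step exchanges one ring group for another on the nitrogen, with the rest of the shared core unchanged. In this assay the exchange of 3-bromophenyl for 3,4-dimethoxyphenyl gives a 1.6-fold higher number from compound 3 to compound 4 (0.21 log units; within the scatter), so this assay does not separate the two groups, even though bromine leaves, oxygen enters, and the entering group carries hydrogen-bond acceptors that the leaving group lacks. Nothing in the available evidence bears on why these two ring groups read so alike.

This single pair changes several things at once, so it cannot show what the loss of the bromine or the gain of each methoxy group contributes alone; a plain phenyl or a phenyl with a single methoxy group would help pull those apart. As far as these compounds go, it also remains open how far this similarity extends among ring groups, for example to a pyridine ring in place of the benzene ring, or to a phenyl ring carrying a carboxylic acid or an amine, and whether any such group would move the number beyond the scatter.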